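A Sulfonyl Group Replaces the Carbamoyl on the Core Nitrogen

The source may report more compounds than this note shows. Statements on the series, on what has been measured and on what is new or still open speak of the compounds shown alone.

Compound 1 `C=CCNC(=O)n1c(-c2ccc(OC)cc2)cc(=O)c2c(OC)cc(OC)cc21`: 12000 nM
Compound 2 `COC(=O)c1cc(=O)c2c(OC)cc(OC)cc2[nH]1`: > 34400 nM, a limit
Compound 3 `COC(=O)c1cc(=O)c2c(OC)cc(OC)cc2n1C`: > 19000 nM, a limit

All three compounds share one core and were tested in a functional assay on SEM cells (Homo sapiens) for antiproliferative activity, with a stated time of 72 h; a lower number here means that less compound is needed, a higher number that more compound is needed for the effect. Among the values shown, compound 1 stands alone with a real number, 12000 nM. For compound 2 this assay gives only a limit, > 34400 nM. For compound 3 it likewise gives only a limit, > 19000 nM. Among the compounds with values here, the single step between measured compounds, a step that the two limits leave unreadable from compound 2 to compound 3, therefore cannot be sized: one end rests at the limit of > 34400 nM in this assay, at which 1 of the 3 values shown sits, the other at the limit of > 19000 nM in this assay, at which 1 of the 3 values shown sits.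

The new compound 4 `COc1ccc(-c2cc(=O)c3c(OC)cc(OC)cc3n2S(=O)(=O)c2ccc(C#N)cc2)cc1` arises from compound 1 by (4-cyanophenyl)sulfonyl in place of allylcarbamoyl on an aromatic nitrogen. Within the data shown here, no measured step concerns this exchange: the one step that exists changes a hydrogen for a methyl on that nitrogen, and even its size is unreadable. There is thus no basis for expecting a shift beyond the usual scatter in either direction in this assay, and an estimate can only lean on the value of compound 1.

Compound 4 is expected to give about 12000 nM in this assay, within a broad range from 3000 nM to 40000 nM. This estimate means an expected step of no change at the digits printed from compound 1 to compound 4 (within the scatter), which stays within the scatter.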

Compound 4, half-maximal effective concentration: 1300 nM
Estimate against measurement, compound 4: 9.2-fold (0.97 log units) above; measured number outside the range, below it.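

Putting (4-cyanophenyl)sulfonyl in place of allylcarbamoyl on the aromatic nitrogen gives a 9.2-fold lower number from compound 1 to compound 4 (0.97 log units; beyond the scatter) in this assay, the first readable sign that the group on this nitrogen can move the number beyond the usual scatter. Within the data shown here, the earlier compounds could not show this, as their only step at this nitrogen, methyl in place of hydrogen, runs between two limits and cannot be read. The exchange alters several things at once, bringing in a six-membered aromatic ring and a nitrile and removing the hydrogen-bond donor, and no measured property shown here bears on why the number falls.

As far as these compounds go, it stays open which part of the entering group matters: the sulfonyl link, the aromatic ring or the nitrile, a question that a plain benzenesulfonyl or a small methanesulfonyl group on the same nitrogen would help to settle. Also open, from the compounds shown here alone, is whether the same exchange would lower the number when the 4-methoxyphenyl group on the shared core is replaced, for example by a carboxylic acid or an amine.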